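The compounds below may be only part of what the source reports. "The series", "measured", "known", "first", "only" and "open" are said of these compounds alone.

Working notes on the series. Compound 1 `CC(=O)N1CCC(C(=O)N2N=CC[C@H]2c2ccccc2)CC1` gives 6300 nM in an assay on L929 cells for inhibition of receptor-interacting serine/threonine-protein kinase 1 (Mus musculus), read by luminescence, with a stated time of 24 h (a lower number here means a stronger inhibitor, a higher number a weaker inhibitor), whereas compound 2 `Cc1nnc(N2CCC(C(=O)N3N=CC[C@H]3c3cc(F)cc(F)c3)CC2)o1` gives 3.2 nM in this assay, the lower of the two numbers, with a gap well beyond the scatter. Compound 3 `N#Cc1cc(N2CCC(C(=O)N3N=CC[C@H]3c3cc(F)cc(F)c3)CC2)ncn1` keeps the core of compound 2 and differs only in a group of 8 heavy atoms (5 carbon, 3 nitrogen; one six-membered aromatic ring with 2 hetero atoms) in place of a group of 6 heavy atoms (3 carbon, 2 nitrogen, 1 oxygen; one five-membered aromatic ring with 3 hetero atoms), on an amine nitrogen in a ring. For the measured compounds named here, no measured pair shows this exchange. In this assay the expected step is small, with no clear direction and likely within the scatter, as a 1.3-fold higher number from compound 2 to compound 3 (0.10 log units; within the scatter). Compound 3 is estimated at 4 nM, in a range from 1.5 nM to 12 nM.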

Compound 3, half-maximal inhibitory concentration: 32 nM
Estimate against measurement, compound 3: 8.0-fold (0.90 log units) below, and the stated range ends below it.
By their numbers in this assay, from the lowest: compound 2; then compound 3; then compound 1.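

At the amine nitrogen in the ring, the group is not freely exchangeable: replacing 5-methyl-1,3,4-oxadiazol-2-yl with the six-membered aromatic ring bearing a nitrile gives a 10-fold higher number from compound 2 to compound 3 (1.00 log units; beyond the scatter) in this assay. The two groups have equal counts of hydrogen-bond donors and acceptors, and neither has a net charge, so these counts do not separate them. Nothing on hand gives a reason for the step. The exchange alters ring size, hetero atoms and the nitrile together, leaving their separate contributions open. Also open, from the compounds shown here alone, is how an ethyl or a primary amine in place of the methyl on the oxadiazole would read.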